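Trading a spiro diamine for an azepane ring

The source may report more compounds than this note shows. Statements on the series, on what has been measured and on what is new or still open speak of the compounds shown alone.

Compound 1 `CN(c1ccc2cc(NC(=O)CCc3ccc(C(F)(F)F)cc3)ccc2n1)C1CCCC1` gives 350 nM in a functional assay on HEK293 cells for activation of melanin-concentrating hormone receptor 1 (Rattus norvegicus), read by inositol phosphate accumulation; a lower number here means that less compound is needed, a higher number that more compound is needed for the effect.
Compound 2 `CC(C)C(=O)NC1CCN(c2ccc3cc(NC(=O)CCc4ccc(C(F)(F)F)cc4)ccc3n2)C1` gives 90 nM in this assay.
Compound 3 `O=C(CCc1ccc(C(F)(F)F)cc1)Nc1ccc2nc(N3CCC4(CCNC4)C3)ccc2c1` gives 140 nM in this assay.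

Among these three numbers, compound 3 has the second highest; compound 2 sits within the scatter of it, while compound 1 lies beyond it, as the step of a 2.5-fold lower number from compound 1 to compound 3 (0.40 log units; beyond the scatter) shows. Compound 4 `O=C(CCc1ccc(C(F)(F)F)cc1)Nc1ccc2nc(N3CCCCCC3)ccc2c1` is the new structure: a group of 7 heavy atoms (6 carbon, 1 nitrogen; one seven-membered non-aromatic ring with 1 hetero atom) in place of a group of 9 heavy atoms (7 carbon, 2 nitrogen; 2 five-membered non-aromatic rings with 1 hetero atom each), on an aromatic carbon. This change bears on the step from compound 1 to compound 3, where a group of 7 heavy atoms with one ring and no hydrogen-bond donor was replaced by the 9-atom spiro group, and the number fell a 2.5-fold lower number from compound 1 to compound 3 (0.40 log units; beyond the scatter). Compound 4 returns to a 7-atom single-ring amine without a donor, so a modest rise toward the number of compound 1 is expected, a 2.1-fold higher number from compound 3 to compound 4 (0.33 log units; beyond the scatter). Compound 4 is therefore estimated at 300 nM, within 120 nM to 800 nM.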

Compound 4, half-maximal effective concentration: 1800 nM
Estimate against measurement, compound 4: 6.0-fold (0.78 log units) below; the measured number lies above the stated range.
By their numbers in this assay, from the lowest: compounds 2 and 3 (each within the scatter of the next); then compound 1; then compound 4.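

Placing azepan-1-yl on this aromatic carbon moves the number further than any earlier change here: a 13-fold higher number from compound 3 to compound 4 (1.11 log units; beyond the scatter), a 20-fold higher number from compound 2 to compound 4 (1.30 log units; beyond the scatter) and a 5.1-fold higher number from compound 1 to compound 4 (0.71 log units; beyond the scatter). That last step joins two groups of 7 heavy atoms, so heavy-atom count alone does not set the number at this position. Nothing shown gives a cause for this rise. On these data alone, it remains open whether the six-membered piperidin-1-yl behaves like azepan-1-yl, and whether adding an amine to the azepane ring would bring the number back down.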